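Swapping a dimethylamino for a trifluoromethyl on a pyrazolopyrimidine

The source may report more compounds than this note shows. Statements on the series, on what has been measured and on what is new or still open speak of the compounds shown alone.

Compound 2 `COc1cc(-c2ccnc3cc(-c4ccc(N(C)C)cc4)nn23)cc(OC)c1OC` was tested in a functional assay on HeLa cells (Homo sapiens) for inhibition, read by CCK-8 assay, with a stated time of 48 h (a higher number here means a weaker inhibitor, a lower number a stronger inhibitor), and gives 378 nM, the lowest of the two real numbers shown. Compound 3 `COc1cc(-c2ccnc3cc(-c4cn(C(=O)OC(C)(C)C)c5ccccc45)nn23)cc(OC)c1OC` gives 3770 nM, a higher number that lies beyond the scatter. Compound 1 `Cc1ccc(-c2cc3nccc(-c4ccc(F)cc4)n3n2)cc1` reaches only a limit of the assay, > 10000 nM; this limit is noted as the limit of > 10000 nM in this assay, at which 1 of the 3 values shown sits.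

Compound 4 `COc1cc(-c2ccnc3cc(-c4ccc(C(F)(F)F)cc4)nn23)cc(OC)c1OC` is compound 2 with one change: trifluoromethyl in place of dimethylamino on an aromatic carbon. Among the compounds with values here, no pair of measured compounds differs in exactly this way, so the step is a guess. A moderate loss of potency is expected, larger than the scatter but well short of the limit.

The step from compound 2 to compound 4 is estimated at a 4.0-fold higher number from compound 2 to compound 4 (0.60 log units; beyond the scatter). Compound 4 is thus expected to give 1500 nM, with a range from 400 nM to 6000 nM.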

Compound 4, half-maximal inhibitory concentration: 1840 nM
Compound 4: the middle estimate sits 1.2-fold (0.09 log units) below what was measured, within the range that was stated.
By their numbers in this assay, from the lowest: compound 2; then compound 4; then compound 3. At a limit, above all of these: compound 1.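

In this assay, replacing dimethylamino with trifluoromethyl gives a 4.9-fold higher number from compound 2 to compound 4 (0.69 log units; beyond the scatter), the only step shown between compounds that differ in just one place. The group on this aromatic carbon therefore affects the number, although the change is modest and compound 4 still gives a real value rather than a limit of the assay.

A single pair cannot show how other groups would behave here, such as a methoxy, a primary amine or a carboxylic acid. Nothing shown here explains the size of this step.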